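From Ethyl to Bromo: What Compound 4 May Show

This account rests on a few compounds, and the source may have more. Where it says the series, first, only, none or still open, it means among the compounds named here.

Measured in a functional assay on K562 cells (Homo sapiens) for antiproliferative activity, read by sulforhodamine B assay, with a stated time of 48 h; on this read-out higher numbers stand for weaker inhibition and lower numbers for stronger inhibition:
Compound 1 `Cc1cccc(NS(=O)(=O)c2ccc(N3CCNC3=O)cc2)c1`: 200 nM
Compound 2 `CCc1cccc(NS(=O)(=O)c2ccc(N3CCNC3=O)cc2)c1`: 230 nM
Compound 3 `COc1cc(NS(=O)(=O)c2ccc(N3CCNC3=O)cc2)cc(OC)c1OC`: 19 nM

At 230 nM, compound 2 lies within the scatter of compound 1, while compound 3 shows a much lower number, 19 nM. The next compound to be tested is compound 4 `O=C1NCCN1c1ccc(S(=O)(=O)Nc2cccc(Br)c2)cc1`. It departs from compound 2 by one change, bromo in place of ethyl on an aromatic carbon.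

For the measured compounds named here, only one measured step bears on this change. It alters the same substituent and gives a 1.2-fold higher number from compound 1 to compound 2 (0.06 log units; within the scatter), which stays within the scatter. Going by the values given here, compound 3 differs from compound 2 in more than one place and offers no clean step, and no bromo compound has been measured. A shift beyond the scatter in this assay is therefore not expected, and no direction can be favoured with confidence. The estimate amounts to a 1.2-fold lower number from compound 2 to compound 4 (0.06 log units; within the scatter), an expected change within the scatter. Compound 4 is expected to give about 200 nM, with an estimated range from 80 nM to 500 nM.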

Compound 4, half-maximal inhibitory concentration: 87 nM
Beside the measured number, compound 4's estimate is 2.3-fold (0.36 log units) above it; the measured number falls inside the stated range.
By their numbers in this assay, from the lowest: compound 3; then compound 4; then compounds 1 and 2 (each within the scatter of the next).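

In this assay, the earlier step among alkyl groups at this place stayed within the scatter (a 1.2-fold higher number from compound 1 to compound 2 (0.06 log units; within the scatter)), so the place had not yet shown any response to a change of group. Bromo shows that it can respond: the number falls beyond the scatter both against ethyl (a 2.6-fold lower number from compound 2 to compound 4 (0.42 log units; beyond the scatter)) and against methyl (a 2.3-fold lower number from compound 1 to compound 4 (0.36 log units; beyond the scatter)), although both steps are modest. No measurement at hand accounts for this shift.

With a single halogen shown, it remains open whether the shift is particular to bromo or would also appear with chloro or iodo at the same place. How an amine, a carboxylic acid or a longer chain would fare there also remains open, as the compounds shown give no step for any of them.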